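Two Nitro Esters at the Limit, and a Third

This account rests on a few compounds, and the source may have more. Where it says the series, first, only, none or still open, it means among the compounds named here.

compound 1 `CC(C)(NC(=O)COC(=O)c1ccc([N+](=O)[O-])o1)c1ccccc1`: > 100000 nM
compound 2 `CC(=O)Oc1ccc(CN(C(=O)COC(=O)c2ccc([N+](=O)[O-])o2)C(C)(C)C)cc1`: > 100000 nM

In an ADME assay on MT4 cells (Homo sapiens) for cytotoxicity, read by MTT assay, with a stated time of 3 days (on this read-out higher numbers stand for lower toxicity in this test and lower numbers for higher toxicity in this test), compound 2 gives > 100000 nM, which is a limit of the assay and not a number. Compound 1 gives > 100000 nM, which is likewise a limit. Neither compound therefore has an exact value, and the record so far reads: the limit of > 100000 nM in this assay, at which 2 of the 2 values shown sit.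

Compound 3 `CC(C)(C)N(Cc1ccc(C(F)(F)F)cc1)C(=O)COC(=O)c1ccc([N+](=O)[O-])o1` carries trifluoromethyl in place of the acetoxy of compound 2, on an aromatic carbon, para to a large group: trifluoromethyl in place of acetoxy on an aromatic carbon. Going by the values given here, no measured step exists to gauge such a change in this assay, so the expectation rests only on that shared limit, (the limit of > 100000 nM in this assay, at which 2 of the 2 values shown sit). The step of an at least 1.1-fold lower number from compound 2 to compound 3 (0.04 log units; that floor lies within the scatter) is expected to stay within the usual scatter, and any larger move is expected to be downward, towards higher toxicity. For compound 3 the estimated value is 90000 nM, with an expected range from 30000 nM to 200000 nM.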

Compound 3, half-maximal cytotoxic concentration: 71000 nM
Estimate against measurement, compound 3: 1.3-fold (0.10 log units) above, within the range that was stated.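

Trifluoromethyl in place of acetoxy on an aromatic carbon, para to a large group, gives an at least 1.4-fold lower number from compound 2 to compound 3 (0.14 log units; that floor lies within the scatter), and that floor is all that can be read, since the step starts from a limit. Going by these compounds alone, compound 3, at 71000 nM, holds the first exact value in this assay, so this position now has a number to which later changes can be compared, although the true size of this step remains unknown. The rest of the record has not moved from where it stood: the limit of > 100000 nM in this assay, at which 2 of the 3 values shown sit.

As far as these compounds go, whether a nitrile or an amine on the same aromatic carbon would read like trifluoromethyl or like acetoxy stays open. Within the data shown here, with only this one step at hand, it is also open whether the same change would read alike on the core of compound 1.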